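From Carboxyethenyl to Carboxyphenyl on an Antiproliferative Scaffold

A few compounds are considered here, and "the series" means these few. Any claim that something is new, unique, unknown or untested is made for them only; others in the source may bear on it.

Within the data shown here, in a functional assay on NCI-H441 cells (Homo sapiens) for antiproliferative activity, with a stated time of 24 h (on this read-out lower numbers stand for stronger inhibition and higher numbers for weaker inhibition), only two compounds have numbers so far. Compound 1 (`O=C1/C(=C/c2ccccc2Br)CNC/C1=C\c1ccccc1Br`) gives 6000 nM, and compound 2 (`O=C(O)/C=C/C(=O)N1C/C(=C\c2ccccc2F)C(=O)/C(=C/c2ccccc2F)C1`) gives 29000 nM. Compound 2 therefore holds the higher of the two numbers, which means weaker inhibition, and the gap between them lies beyond the usual scatter of repeated measurements.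

Compound 3 (`O=C1/C(=C/c2ccccc2F)CN(C(=O)c2ccccc2C(=O)O)C/C1=C\c1ccccc1F`) has not yet been measured. It differs from compound 2 in one place, with 2-carboxyphenyl in place of 2-carboxyethenyl on a carbonyl carbon. Among the measured compounds shown here, no measured pair shows this swap, so the expectation rests on compound 2 alone, at 29000 nM. The expected step, a 1.3-fold lower number from compound 2 to compound 3 (0.12 log units; within the scatter), is small, slightly towards a lower number and not beyond the scatter. In this assay, the estimate for compound 3 is 22000 nM, with an expected range from 8000 nM to 60000 nM.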

Compound 3, half-maximal inhibitory concentration: 56000 nM
Compound 3: the middle estimate sits 2.5-fold (0.41 log units) below what was measured, within the range that was stated.
By their numbers in this assay, from the lowest: compound 1; then compounds 2 and 3 (each within the scatter of the next).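

In this assay, putting 2-carboxyphenyl in place of 2-carboxyethenyl on the carbonyl carbon gives a 1.9-fold higher number from compound 2 to compound 3 (0.29 log units; within the scatter), so compound 2 and compound 3 cannot be told apart on this read-out. This shows that a group of 9 heavy atoms with a six-membered aromatic ring can stand at this place, where a ringless group of 5 heavy atoms stood, without a change beyond the usual scatter. No measurement shown here offers an explanation for this result.

From the compounds shown here alone, both groups at this place carry a carboxylic acid, so its own contribution remains open. A plain phenyl group or a chain ending in an amine on the same carbonyl carbon would test whether the read-out depends on that acid.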